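A few compounds are considered here, and "the series" means these few. Any claim that something is new, unique, unknown or untested is made for them only; others in the source may bear on it.

Compound 1 `O=S(=O)(/C=C/c1ccccn1)c1ccc(F)cc1` is the reference point of this small set. In an assay on U2OS cells for activation of nuclear factor erythroid 2-related factor 2 (Homo sapiens), read by beta-arrestin recruitment, with a stated time of 6 h (a lower number here means that less compound is needed, a higher number that more compound is needed for the effect), compound 1 gives 3100 nM, the highest number among the three measured compounds. Compound 2 `O=S(=O)(/C=C/c1ncccc1F)c1ccc(F)cc1` gives 542 nM, and compound 3 `O=S(=O)(/C=C/c1ncccc1Cl)c1ccc(F)cc1` gives 231 nM. The change from compound 1 to compound 4 `O=S(=O)(/C=C/c1ccc(Cl)cn1)c1ccc(F)cc1` is chloro in place of hydrogen on an aromatic carbon, at a place two atoms from the ring nitrogen, para to a large group. For the measured compounds named here, the steps that bear on it are a 13-fold lower number from compound 1 to compound 3 (1.13 log units; beyond the scatter) and a 5.7-fold lower number from compound 1 to compound 2 (0.76 log units; beyond the scatter), although in those compounds the halogen occupies a different place on the shared core; a 2.3-fold lower number from compound 2 to compound 3 (0.37 log units; beyond the scatter) puts chloro ahead of fluoro. The step expected for compound 4 is therefore a more modest one, estimated as a 3.9-fold lower number from compound 1 to compound 4 (0.59 log units; beyond the scatter). Compound 4 is estimated at 800 nM, within a range from 250 nM to 2500 nM.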

Compound 4, half-maximal effective concentration: 4370 nM
Compound 4: middle estimate off by 5.5-fold (0.74 log units), on the low side, and the stated range ends below it.
By their numbers in this assay, from the lowest: compound 3; then compound 2; then compounds 1 and 4 (each within the scatter of the next).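

In this assay, chloro in place of hydrogen at this place, two atoms from the ring nitrogen and para to a large group, leaves the number within the scatter (a 1.4-fold higher number from compound 1 to compound 4 (0.15 log units; within the scatter)). The same exchange at the place occupied by the halogen in compound 3 gives a large step (a 13-fold lower number from compound 1 to compound 3 (1.13 log units; beyond the scatter)), so the step for chloro differs with its place on the shared core. Nothing measured here accounts for that contrast. The compounds shown leave open how fluoro, methoxy or an amine would read at this place. They also leave open whether a second halogen would add to the step seen for compound 3.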